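Methoxy for Tert-Butyl on a Carbapenem Ester

The source may report more compounds than this note shows. Statements on the series, on what has been measured and on what is new or still open speak of the compounds shown alone.

Compound 1 `C[C@@H](O)[C@H]1C(=O)N2C(C(=O)OCOC(=O)C(C)(C)C)=C(S[C@@H]3CN[C@H](C(=O)Nc4cccc(C(=O)O)c4)C3)[C@H](C)[C@H]12` stands, in an ADME assay on a cell-free system (plasma, Rattus norvegicus) for metabolic stability, read by LC-MS, with a stated time of 60 min, at 37 degrees C, tested at 50 uM (on this read-out lower numbers stand for a less stable compound and higher numbers for a more stable compound), at 0%, level with compound 2 `CCOC(=O)C1=C(S[C@H]2C[C@@H](C(=O)Nc3cccc(C(=O)OCC)c3)N(C(=O)OCc3oc(=O)oc3C)C2)[C@H](C)[C@@H]2[C@@H]([C@@H](C)O)C(=O)N12`, which gives 0%; together they are the lowest of the three numbers. Compound 3 `C[C@@H](O)[C@H]1C(=O)N2C(C(=O)OCOC(=O)C(C)(C)C)=C(S[C@@H]3CN[C@H](C(=O)Nc4cccc(C(=O)OCOC(=O)C(C)(C)C)c4)C3)[C@H](C)[C@H]12` gives 2%, and the step of a number 2 percentage points higher from compound 1 to compound 3 (within the scatter) is within the scatter. Compound 4 `COC(=O)OCOC(=O)C1=C(S[C@@H]2CN[C@H](C(=O)Nc3cccc(C(=O)O)c3)C2)[C@H](C)[C@@H]2[C@@H]([C@@H](C)O)C(=O)N12` differs from compound 1 in one place: methoxy in place of tert-butyl on a carbonyl carbon. Among the compounds with values here, no measured step concerns this carbonyl carbon; the single step, from compound 1 to compound 3, lies elsewhere in the molecule and was within the scatter, and all three numbers sit at the bottom of the scale. Compound 4 is therefore expected to stay there, the step of a number 2 percentage points higher from compound 1 to compound 4 (within the scatter) being expected to be none beyond the scatter. The estimate for compound 4 is 2%, with a range from 0% to 12%.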

Compound 4, percent of the compound remaining: 0%
The estimate for compound 4 lay 2 percentage points above the measured number; the measured number falls inside the stated range.
By their numbers in this assay, from the lowest: compounds 1, 2, 4 and 3 (each within the scatter of the next).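

In this assay, within the data shown here, methoxy in place of tert-butyl on a carbonyl carbon reads no change at the digits printed from compound 1 to compound 4 (within the scatter) and gives the first step at this position, since the only earlier step lay elsewhere in the molecule. The ((methoxycarbonyl)oxy)methyl ester therefore sits at the bottom of the scale, as the (((tert-butyl)carbonyl)oxy)methyl ester does. Nothing available explains this result. Still open is whether an amine or a longer chain on this carbonyl carbon would leave more of the compound remaining, since both groups shown here give numbers at the floor.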